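A bicyclic amide substituent and its expected binding

This account rests on a few compounds, and the source may have more. Where it says the series, first, only, none or still open, it means among the compounds named here.

Compound 1 `NC(=O)[C@H]1OC(n2cnc3c(N)ncnc32)[C@H](O)[C@@H]1O` — 64 nM
Compound 2 `Nc1ncnc2c1ncn2[C@@H]1O[C@H](C(=O)NC2CCCC2)[C@@H](O)[C@H]1O` — 49 nM
Compound 3 `C[C@H]1CC[C@@H](NC(=O)[C@H]2O[C@@H](n3cnc4c(N)ncnc43)[C@H](O)[C@@H]2O)CC1` — 55.6 nM

In an assay on cell membranes for binding affinity to 2-oxoglutarate receptor 1 (Rattus norvegicus), read by radioligand binding (a lower number here means a stronger inhibitor, a higher number a weaker inhibitor), compound 1 gives the highest of the three numbers; compound 3 is nearest and compound 2 furthest, and both gaps lie within the scatter. Compound 4 `Nc1ncnc2c1ncn2C1O[C@H](C(=O)NC2CC3CCC2C3)[C@@H](O)[C@H]1O` differs from compound 1 by a group of 7 heavy atoms (7 carbon; 2 five-membered non-aromatic rings of carbon only) in place of a hydrogen atom, on an amide-type nitrogen. For the measured compounds named here, no step from compound 1 to another measured compound is given; the only measured step, a 1.1-fold higher number from compound 2 to compound 3 (0.05 log units; within the scatter), exchanges one ring group on the amide-type nitrogen for another and stays within the scatter. The numbers of compound 1, compound 2 and compound 3 all lie within the scatter of one another. Compound 4 is therefore expected to show no step beyond the scatter, a 1.3-fold lower number from compound 1 to compound 4 (0.11 log units; within the scatter). The estimated value of compound 4 is 50 nM, with a range from 25 nM to 100 nM.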

Compound 4, inhibition constant: 640 nM
The estimate for compound 4 lay 13-fold (1.11 log units) below the measured number; the whole stated range lies below it.
By their numbers in this assay, from the lowest: compounds 2, 3 and 1 (each within the scatter of the next); then compound 4.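

In this assay, for the compounds shown here, a group with 2 five-membered non-aromatic rings of carbon only on the amide-type nitrogen gives a 10-fold higher number from compound 1 to compound 4 (1.00 log units; beyond the scatter), the first step at this position that lies beyond the scatter. Cyclopentyl in compound 2 and 4-methylcyclohexyl in compound 3 remain within the scatter of compound 1, so this position does not accept every carbon ring group alike. No evidence at hand accounts for this result. The compounds shown leave open whether an ethyl group, a longer chain or a chain ending in a carboxylic acid on this nitrogen would stay near compound 1 or fall near compound 4.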